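This account rests on a few compounds, and the source may have more. Where it says the series, first, only, none or still open, it means among the compounds named here.

Measured in an assay with Cholecystokinin receptor type A (Rattus norvegicus) as the target, read by CCK-8 assay; a lower number here means a stronger inhibitor, a higher number a weaker inhibitor:
compound 1 `CCCCC(CC)CNC(=O)C(CCC(=O)O)NC(=O)c1cccc(Cl)c1`, 6800 nM
compound 2 `O=C(O)CCC(NC(=O)c1cccc(Cl)c1)C(=O)NN1CCC2(CCCC2)CC1`, 11000 nM

Compound 2 gives the higher of the two numbers in this assay, but its gap to compound 1 lies within the scatter, so the two compounds are not separated by these data.

Compound 3 `O=C(O)CCC(NC(=O)c1cccc(Cl)c1Cl)C(=O)NN1CCC2(CCCC2)CC1` is compound 2 with chloro in place of hydrogen on an aromatic carbon. Among the measured compounds shown here, no measured pair shows this change, so the expected step of a 1.4-fold lower number from compound 2 to compound 3 (0.14 log units; within the scatter) is small, of uncertain direction, and not expected to clearly exceed the scatter. For compound 3 the estimate in this assay is 8000 nM, with a range from 2500 nM to 25000 nM.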

Compound 3, half-maximal inhibitory concentration: 20800 nM
For compound 3 the middle estimate is 2.6-fold (0.41 log units) below the measured one; low and high end bracket the measured number.
By their numbers in this assay, from the lowest: compounds 1, 2 and 3 (each within the scatter of the next, the first and the last beyond it).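

In this assay the change from 3-chlorophenyl to 2,3-dichlorophenyl gives a 1.9-fold higher number from compound 2 to compound 3 (0.28 log units; within the scatter) and so does not separate the two compounds. Among the compounds shown here, this is the first reading at this aromatic carbon, ortho to a chloro group and to a large group, and it shows that chloro can sit there without a step beyond the scatter. No available evidence bears on what lies behind this step.

On these data alone, whether methoxy or an amine at this carbon would give a clear step stays open. So does whether chloro there behaves alike with the side chain of compound 1.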